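Swapping Hydroxy for Aminomethyl on a Short Side Chain

The source may hold more compounds than are shown below. What is called first, only, known or untested is meant among the compounds shown, and "the series" means these compounds.

Of the compounds shown here, three have been measured so far in a physicochemical assay for lipophilicity, read by HPLC; on this read-out lower numbers stand for lower lipophilicity and higher numbers for higher lipophilicity. Compound 1 (`Cc1ccsc1C(=CCCN(C)C(CCN)C(=O)NCc1ccc(Cl)cc1)c1sccc1C`) gives 5.85, compound 2 (`Cc1ccsc1C(=CCCN(C)C(CCO)C(=O)NCc1ccc(F)cc1)c1sccc1C`) gives 5.87, and compound 3 (`Cc1ccsc1C(=CCCN(C)C(CO)C(=O)NCc1ccc(F)cc1)c1sccc1C`) gives 6.45. That last number is the highest of the three and stands beyond the scatter from both others.

Compound 4 (`Cc1ccsc1C(=CCCN(C)C(CCN)C(=O)NCc1ccc(F)cc1)c1sccc1C`) has not yet been measured. It differs from compound 3 by having aminomethyl in place of hydroxy on a saturated chain carbon, two bonds along the chain from an amine nitrogen and a carbonyl carbon. Cut one bond further out, the same difference reads hydroxymethyl to 2-aminoethyl.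

Among the measured compounds shown here, one measured step bears directly on this, at the same place: a number 0.58 log units higher from compound 2 to compound 3 (beyond the scatter). It is modest, and read in reverse it points to a lower number for the longer group. Compound 1 already carries 2-aminoethyl and shows 5.85, while compound 2 shows 5.87, and these two numbers lie within the scatter of each other. However, compound 1 also differs from compound 4 elsewhere, and that difference has not been measured alone, so some caution is needed. The expected change is a fall, a number 0.75 log units lower from compound 3 to compound 4 (beyond the scatter). For compound 4 the estimated value is 5.7, with an expected range from 5.35 to 6.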

Compound 4, partition coefficient: 6.45
Compound 4: middle estimate off by 0.75 log units, on the low side; measured number above the stated range.
By their numbers in this assay, from the lowest: compounds 1 and 2 (each within the scatter of the next); then compounds 3 and 4 (each within the scatter of the next).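

In this assay, aminomethyl in place of hydroxy gives no change at the digits printed from compound 3 to compound 4 (within the scatter), so at this position hydroxymethyl and 2-aminoethyl cannot be told apart on this read-out. The atom at the end of the chain still matters, since amino in place of hydroxy, on a saturated chain carbon, three bonds along the chain from an amine nitrogen and a carbonyl carbon, gives a number 0.58 log units higher from compound 2 to compound 4 (beyond the scatter). Among the compounds shown here, the halogen, which the earlier compounds could not separate from other differences, matters too: fluoro in place of chloro on an aromatic carbon gives a number 0.60 log units higher from compound 1 to compound 4 (beyond the scatter), so in this pair the lower number goes with chloro while 2-aminoethyl stays the same.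

Nothing in the data shown explains why these numbers fall as they do. As far as these compounds go, it also remains open whether a 3-aminopropyl chain or a carboxylic acid at this position would stay level with compound 3 and compound 4, and whether the step from chloro to fluoro would be the same size on a 2-hydroxyethyl side chain.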